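The source may hold more compounds than are shown below. What is called first, only, known or untested is meant among the compounds shown, and "the series" means these compounds.

Measured compounds in this series:

Compound 1 is `Cc1ccc(NC(=O)Nc2cc(C)nc3ccccc23)cc1`. In an ADME assay on BJ cells (Homo sapiens) for cytotoxicity, with a stated time of 72 h (a higher number here means that more compound is needed for the effect, a lower number that less compound is needed), compound 1 gives > 25000 nM, which is a limit of the assay and not a number.
Compound 2 is `COC(=O)c1ccc(NC(=O)Nc2cc(C)nc3ccccc23)cc1`. In this assay compound 2 gives 21000 nM.
Compound 3 is `Cc1cc(NC(=O)Nc2ccccc2N)c2ccccc2n1`. In this assay compound 3 gives > 25000 nM, again a limit of the assay.

Within the data shown here, compound 2 therefore stands as the only actual number in this assay; the other two values are limits, as the limit of > 25000 nM in this assay, at which 2 of the 3 values shown sit, records. Compound 4 is `Cc1cc(NC(=O)Nc2ccc(OC(F)(F)F)cc2)c2ccccc2n1` and differs from compound 2 by trifluoromethoxy in place of methoxycarbonyl on an aromatic carbon.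

Among the measured compounds shown here, two measured steps bear on this change. The step of an at least 1.1-fold lower number from compound 1 to compound 2 (0.07 log units; that floor lies within the scatter) shows that swapping a methyl for a methoxycarbonyl at this position moved the read-out by no more than the scatter. The step that the two limits leave unreadable from compound 1 to compound 3 gives no readable size. Nothing in these steps suggests a shift beyond the scatter for the trifluoromethoxy substitution, so a step of about a 1.2-fold higher number from compound 2 to compound 4 (0.08 log units; within the scatter) is expected, with the result likely to land at or near the assay limit.

Compound 4 is estimated at 25000 nM, with a range from 12000 nM to 60000 nM.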

Compound 4, half-maximal effective concentration: 25000 nM
The estimate for compound 4 equals the measured number at the digits printed; measured number inside the range.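

At this position, trifluoromethoxy in place of methoxycarbonyl gives a 1.2-fold higher number from compound 2 to compound 4 (0.08 log units; within the scatter), so this assay does not separate the two groups. Among these compounds, compound 4 supplies a second actual number in a series that previously held only one, and this is the first readable comparison between two measured numbers at this position. The other new step, a number no higher from compound 1 to compound 4 (the limit leaves the size open), cannot be read, and limits still stand among the values shown: the limit of > 25000 nM in this assay, at which 2 of the 4 values shown sit.

From the compounds shown here alone, whether a carboxylic acid or a longer alkyl chain at this position would give a step beyond the scatter remains open. The compounds shown also leave open whether any group here would bring the read-out well away from the limit.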